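This account rests on a few compounds, and the source may have more. Where it says the series, first, only, none or still open, it means among the compounds named here.

Measured so far:
compound 1, `O=C(CSc1nnc(-c2ccncc2)o1)N/N=C/c1ccc(F)cc1`, 170000 nM
compound 2, `O=C(CSc1nnc(-c2ccncc2)o1)N/N=C/c1ccccc1F`, 142000 nM
compound 3, `O=C(CSc1nnc(-c2ccncc2)o1)N/N=C/c1ccccc1[N+](=O)[O-]`, 214000 nM

All three share one core and differ only in the aryl group on the carbon with a double bond to nitrogen. In an ADME assay on NIH3T3 cells (Mus musculus) for cytotoxicity, read by MTT assay, with a stated time of 24 h (on this read-out lower numbers stand for stronger inhibition and higher numbers for weaker inhibition), compound 3 gives the highest of the three numbers, but its neighbours lie close: the step of a 1.3-fold higher number from compound 1 to compound 3 (0.10 log units; within the scatter) and the step of a 1.5-fold higher number from compound 2 to compound 3 (0.18 log units; within the scatter) both stay within the scatter, so no ranking among the three can be claimed.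

Compound 4, `O=C(CSc1nnc(-c2ccncc2)o1)N/N=C/c1cc(Cl)ccc1O`, is the next compound. Compared with compound 3 the change is 5-chloro-2-hydroxyphenyl in place of 2-nitrophenyl on a carbon with a double bond to nitrogen. For the measured compounds named here, the steps that bear on it are those that swap this same aryl group: a 1.2-fold lower number from compound 1 to compound 2 (0.08 log units; within the scatter), a 1.3-fold higher number from compound 1 to compound 3 (0.10 log units; within the scatter) and a 1.5-fold higher number from compound 2 to compound 3 (0.18 log units; within the scatter). Each of them is small and within the scatter, so changing the substituents on this aryl ring has not so far moved the read-out noticeably. A hydroxyl and a chloro are new to this set, and nothing measured here speaks to them directly, so the expectation rests on the flatness seen so far.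

For compound 4 the expected step is a 1.2-fold lower number from compound 3 to compound 4 (0.08 log units; within the scatter), that is, nothing beyond the scatter. The estimate for compound 4 in this assay is therefore 180000 nM, with a range from 80000 nM to 400000 nM.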

Compound 4, half-maximal inhibitory concentration: 166000 nM
Compound 4: the middle estimate sits 1.1-fold (0.04 log units) above what was measured, and the stated range covers the measured number.
By their numbers in this assay, from the lowest: compounds 2, 4, 1 and 3 (each within the scatter of the next).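

Compound 4 brings the first hydroxyl and the first chloro to this set, and in this assay its steps to the other three compounds all stay within the scatter: (a 1.3-fold lower number from compound 3 to compound 4 (0.11 log units; within the scatter)) (a 1.2-fold higher number from compound 2 to compound 4 (0.07 log units; within the scatter)) (a 1.0-fold lower number from compound 1 to compound 4 (0.01 log units; within the scatter)). Unlike the 2-nitrophenyl it replaces, the 5-chloro-2-hydroxyphenyl group carries a hydrogen-bond donor, so the flat picture now extends to a group with a donor and to a ring with two different substituents, not just to rings with a single fluoro or nitro. Four different aryl groups on the carbon with a double bond to nitrogen now give numbers that cannot be ranked, and nothing measured here offers an explanation for that flatness.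

The compounds shown leave open whether an amine or a carboxylic acid on this aryl ring, or a cyclohexyl group or a longer alkyl chain in place of the ring, would produce a step beyond the scatter. They also leave open whether a change to the shared core would do so, as that core is identical in all four compounds.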